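Shortening the butyl chain of compound 1 by one carbon

The compounds below may be only part of what the source reports. "The series", "measured", "known", "first", "only" and "open" are said of these compounds alone.

Measured compounds:
compound 1 `CCCC/N=c1\c(O)c(O)\c1=N/Cc1ccc(C#N)cc1` gives > 30000 nM
compound 2 `CCC(C)(C)/N=c1\c(O)c(O)\c1=N/Cc1ccc(F)cc1F` gives 220 nM

The comparison rests on a functional assay for inhibition, with Rattus norvegicus as the target; on this read-out higher numbers stand for weaker inhibition and lower numbers for stronger inhibition. Compound 1 stands at a limit of the assay, not at a number, and this is the limit of > 30000 nM in this assay, at which 1 of the 2 values shown sits. Compound 2 differs from compound 1 in more than one place, so its own value stands on its own; compound 2 in this assay gives 220 nM.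

Compound 3 `CCC/N=c1\c(O)c(O)\c1=N/Cc1ccc(C#N)cc1` has not yet been measured. Its difference from compound 1 is hydrogen in place of methyl on a saturated chain carbon, three bonds along the chain from a double-bonded nitrogen, and, cut one bond further out, it reads as butyl to propyl. Within the data shown here, no measured pair shows what such a change does here, so no step beyond the scatter is expected in either direction, and the estimate for compound 3 in this assay is 40000 nM, within 10000 nM to 150000 nM. The expected step is therefore a step that the limit leaves unreadable from compound 1 to compound 3, with the assay most likely again reporting only a limit for compound 3.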

Compound 3, half-maximal inhibitory concentration: 21900 nM
For compound 3 the middle estimate is 1.8-fold (0.26 log units) above the measured one; measured number inside the range.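

Cutting butyl to propyl at this place turns a limit into a number: this assay shows an at least 1.3-fold lower number from compound 1 to compound 3 (0.13 log units; that floor lies within the scatter) for the loss of that one methyl, and compound 3 gives a readable value where compound 1 did not. This chain position therefore now has a measured reference point with the nitrile-bearing part of the molecule held constant. The true size of the step stays unknown, and only its floor can be stated, as compound 1 carries a limit and not a number: the limit of > 30000 nM in this assay, at which 1 of the 3 values shown sits.

The compounds shown leave open whether an ethyl chain or a pentyl chain at this place would move the number further, and whether a hydroxyl on the propyl chain would be tolerated. They also leave open how much of the value of compound 2 belongs to its branched chain, as it differs from the others in more than one place.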